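Swapping the Cap Group on a Hydroxamic Acid Scaffold

The source may hold more compounds than are shown below. What is called first, only, known or untested is meant among the compounds shown, and "the series" means these compounds.

Measured compounds:
Compound 1, `O=C(CCCCC[C@H](NC(=O)c1ccc(C(F)(F)F)cc1)C(=O)NCc1ccccc1)NO`: 1610 nM
Compound 2, `CN(C)c1ccc(NC(=O)[C@H](CCCCCC(=O)NO)NC(=O)/C=C/c2ccccc2)cc1`: 240 nM
Compound 3, `CN(C)c1ccc(NC(=O)[C@H](CCCCCC(=O)NO)NC(=O)OCc2ccccc2)cc1`: 650 nM

Three hydroxamic acids share a common core and have been tested in a functional assay on NFF cells (Homo sapiens) for antiproliferative activity; on this read-out lower numbers stand for stronger inhibition and higher numbers for weaker inhibition. Compound 3 holds the second highest of the three numbers: compound 1 sits at a higher number, compound 2 at a lower one, and both gaps lie beyond the scatter.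

Compound 4, `CN(C)c1ccc(NC(=O)[C@H](CCCCCC(=O)NO)NC(=O)c2ccc(C(F)(F)F)cc2)cc1`, is the next member and differs from compound 3 only at the cap: 4-(trifluoromethyl)phenyl in place of benzyloxy on a carbonyl carbon. Among the compounds with values here, the single measured step at this position, a 2.7-fold higher number from compound 2 to compound 3 (0.43 log units; beyond the scatter), was modest. Within the data shown here, no step links compound 1 to any other, but it already carries the 4-(trifluoromethyl)phenyl group with a different amide part, and in this assay compound 1 gives 1610 nM, while compound 3 gives 650 nM. Taken together, the data give no clear pull in either direction for compound 4, so no step beyond the scatter is expected.

Compound 4 is therefore estimated at 650 nM in this assay, within a range of 250 nM to 1700 nM. That estimate means a step of no change at the digits printed from compound 3 to compound 4 (within the scatter) and is expected to stay close to compound 3.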

Compound 4, half-maximal inhibitory concentration: 400 nM
Estimate against measurement, compound 4: 1.6-fold (0.21 log units) above, within the range that was stated.
By their numbers in this assay, from the lowest: compounds 2, 4 and 3 (each within the scatter of the next, the first and the last beyond it); then compound 1.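

In this assay, the change on the carbonyl carbon gives a 1.6-fold lower number from compound 3 to compound 4 (0.21 log units; within the scatter) and a 1.7-fold higher number from compound 2 to compound 4 (0.22 log units; within the scatter), so the 4-(trifluoromethyl)phenyl cap cannot be told apart from either benzyloxy or 2-phenylethenyl, even though those two caps differ from each other beyond the scatter. Within the data shown here, compound 4 also gives the first reading of the other varied place, the amide-type nitrogen: with the 4-(trifluoromethyl)phenyl cap held constant, 4-(dimethylamino)phenyl in place of benzyl gives a 4.0-fold lower number from compound 1 to compound 4 (0.60 log units; beyond the scatter) and so lies beyond the scatter. Nothing available explains either result.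

On these data alone, only the 4-(trifluoromethyl)phenyl cap is seen with both amide parts, so it remains open whether the change from benzyl to 4-(dimethylamino)phenyl would read the same with the benzyloxy or 2-phenylethenyl caps. Also open, as far as these compounds go, is how a cap ending in a carboxylic acid or an amine, or a longer chain leading to the hydroxamic acid, would read in this assay.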